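This account rests on a few compounds, and the source may have more. Where it says the series, first, only, none or still open, it means among the compounds named here.

In an ADME assay on microsomes from liver (Rattus norvegicus) for metabolic stability, using NADPH (on this read-out higher numbers stand for fast clearance and lower numbers for slow clearance), compound 1 (`Nc1cc(C(F)(F)F)c(Br)nc1C(=O)NCCC(F)(F)F`) gives 0.0558 mL/min/kg. For compound 2 (`CC(O)(CNC(=O)c1ncc(C(F)(F)F)cc1N)C(F)(F)F`) the assay reports only a limit, < 0.025 mL/min/kg. Compound 3 (`CNc1nc(C(=O)NCC(C)(O)C(F)(F)F)c(N)cc1C(F)(F)F`) differs from compound 2 by methylamino in place of hydrogen on an aromatic carbon, next to the ring nitrogen and ortho to a trifluoromethyl group (methylamino in place of hydrogen on an aromatic carbon). Among the measured compounds shown here, no measured step between compounds covers this change. A small rise in this assay, close to the scatter, is expected, and the estimated change is an at least 1.4-fold higher number from compound 2 to compound 3 (0.14 log units; that floor lies within the scatter). For compound 3 the expected value is 0.035 mL/min/kg, with an estimated range of 0.02 mL/min/kg to 0.09 mL/min/kg.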

Compound 3, clearance: < 0.025 mL/min/kg
Compound 3 ended at the assay's limit; the forecaster's own chance of this, stated with the estimate: 40%; middle value at least 1.4-fold (0.14 log units) from the limit.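

Among the compounds shown here, compound 2 and compound 3 both stand only as limits in this assay, so no step between them can be read: the limit of < 0.025 mL/min/kg in this assay, at which 2 of the 3 values shown sit.

From the compounds shown here alone, whether methylamino in place of hydrogen on an aromatic carbon changes clearance at all stays open.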